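The source may report more compounds than this note shows. Statements on the series, on what has been measured and on what is new or still open speak of the compounds shown alone.

In a functional assay on A549 cells (Homo sapiens) for antiproliferative activity, read by CCK-8 assay, with a stated time of 72 h (a lower number here means a stronger inhibitor of growth, a higher number a weaker inhibitor of growth), three compounds have been measured so far. Compound 1 `CCC1C(=O)N(C)c2cnc(-n3ccc4cc(C(=O)NC)ccc43)nc2N1c1ccn(C)n1` gives 43100 nM, and compound 2 `CCCCNS(=O)(=O)c1ccc(Nc2ncc3c(n2)N(c2ccn(C)n2)C(CC)C(=O)N3C)cc1` gives 10600 nM. Compound 3 `CC[C@@H]1C(=O)N(C)c2cnc(-n3ccc4cc(C(=O)NC(C)C)ccc43)nc2N1C1CCCC1` gives 1780 nM, the lowest of the three numbers; its distance to each of the other two lies beyond the scatter, so compound 3 stands as the strongest growth inhibitor of the set. Compound 4 `CCCCNC(=O)c1ccc2c(ccn2-c2ncc3c(n2)N(C2CCCC2)[C@H](CC)C(=O)N3C)c1` has not yet been measured in this assay. It differs from compound 3 in one place: butyl in place of isopropyl on an amide-type nitrogen. Among the measured compounds shown here, no measured pair shows what such a change does here. With the amide-type nitrogen and the shared core kept, the step is expected to be small, a 1.1-fold higher number from compound 3 to compound 4 (0.05 log units; within the scatter), and not beyond the scatter in either direction. Compound 4 is accordingly estimated at 2000 nM, within 700 nM to 6000 nM.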

Compound 4, concentration for 50% growth inhibition: 1160 nM
Beside the measured number, compound 4's estimate is 1.7-fold (0.24 log units) above it; measured number inside the range.
By their numbers in this assay, from the lowest: compounds 4 and 3 (each within the scatter of the next); then compound 2; then compound 1.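

In this assay, butyl in place of isopropyl on the amide-type nitrogen gives a 1.5-fold lower number from compound 3 to compound 4 (0.19 log units; within the scatter), the first step read at this position. With the shared core kept, the two chains therefore cannot be told apart in this assay, and this one pair shows that the position accepts butyl as well as isopropyl. Nothing available explains this result. Open, from the compounds shown here alone, is whether a longer chain, such as octyl, would also stay within the scatter. Also open, going by these compounds, is what a terminal amine or carboxylic acid on the butyl chain, or a phenyl ring on this nitrogen, would do.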